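Pyrimidine series: substituent on the ring carbon between nitrogens

This account rests on a few compounds, and the source may have more. Where it says the series, first, only, none or still open, it means among the compounds named here.

Measured so far:
compound 1 `CCOC(=O)c1cnc(C)nc1NN1C(=O)C=C(C)C1=O` — 16000 nM
compound 2 `CCOC(=O)c1cnc(SC)nc1NN1C(=O)C=C(C)C1=O` — 200 nM

In a functional assay on Jurkat cells for inhibition of nuclear factor NF-kappa-B complex (Homo sapiens) (on this read-out higher numbers stand for weaker inhibition and lower numbers for stronger inhibition), compound 2 gives 200 nM, the lowest of the two numbers measured; the nearest is compound 1 with 16000 nM. Going by the values given here, the single measured step, an 80-fold lower number from compound 1 to compound 2 (1.90 log units; beyond the scatter), shows that the group on an aromatic carbon of a six-membered aromatic ring with 2 nitrogen, between two ring nitrogen atoms, para to an ethoxycarbonyl group, moves this assay strongly.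

Compound 3 `CCOC(=O)c1cnc(-c2ccccc2)nc1NN1C(=O)C=C(C)C1=O` is not yet measured. Its change from compound 2 is phenyl in place of methylsulfanyl on an aromatic carbon. Among the compounds with values here, no measured step involves phenyl at this position, so the step from methyl to methylsulfanyl only indicates that the position is sensitive, not which way phenyl will go. The expectation is a moderately higher number than compound 2, a 4.0-fold higher number from compound 2 to compound 3 (0.60 log units; beyond the scatter), held with low confidence given the single data point. For compound 3 the estimate in this assay is 800 nM, range 100 nM to 6000 nM.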

Compound 3, half-maximal inhibitory concentration: 100 nM
Compound 3: the middle estimate sits 8.0-fold (0.90 log units) above what was measured; measured number inside the range.
By their numbers in this assay, from the lowest: compounds 3 and 2 (each within the scatter of the next); then compound 1.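

In this assay, the change on the aromatic carbon between two ring nitrogen atoms gives a 2.0-fold lower number from compound 2 to compound 3 (0.30 log units; within the scatter), so methylsulfanyl and phenyl cannot be told apart here, although phenyl brings 6 heavy atoms and one six-membered aromatic ring where methylsulfanyl has 2 heavy atoms. Against methyl, the same place gives a 160-fold lower number from compound 1 to compound 3 (2.20 log units; beyond the scatter), so the large difference seen earlier is not specific to methylsulfanyl or its sulfur: two quite different groups both stand well clear of methyl. No measurement on hand explains this result.

As far as these compounds go, whether an amine or a methoxy group at this position behaves like methylsulfanyl and phenyl, or like methyl, remains open. Also open, from the compounds shown here alone, is whether a longer alkyl chain or a chlorophenyl group keeps the number at the level of compound 2 and compound 3.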